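The source may report more compounds than this note shows. Statements on the series, on what has been measured and on what is new or still open speak of the compounds shown alone.

Three related compounds have been tested in a functional assay on HCT-116 cells (Homo sapiens) for inhibition, read by MTT assay, with a stated time of 72 h; on this read-out lower numbers stand for stronger inhibition of growth and higher numbers for weaker inhibition of growth. Compound 1 `O=C1CC(N2C(=O)CSC2=S)C(=O)N1c1ccc(O)cc1` gives > 100000 nM, and this figure is a limit of the assay, not a number. Compound 2 `O=C1CC(N2C(=O)/C(=C/C(Cl)=C/c3ccc([N+](=O)[O-])cc3)SC2=S)C(=O)N1c1ccc(Cl)cc1` gives 9180 nM. Compound 3 `C=CCOc1ccccc1/C=C1\SC(=S)N(C2CC(=O)N(c3ccc(Cl)cc3)C2=O)C1=O` gives 57200 nM, the higher of the two real numbers in the set, and its gap to compound 2 lies beyond the usual scatter of repeated measurements. Compound 3 therefore shows only weak inhibition of growth, although it does give a real number.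

The next compound, compound 4 `C=CCOc1cccc(/C=C2\SC(=S)N(C3CC(=O)N(c4ccc(Cl)cc4)C3=O)C2=O)c1`, has the same atoms as compound 3, joined differently. It carries 3-(allyloxy)phenyl in place of 2-(allyloxy)phenyl on a double-bonded chain carbon bound to a double-bonded ring carbon. The rest of the molecule stays the same.

Among the measured compounds shown here, no measured pair in this small set isolates a single change, so there is no direct guide to the effect of this move. The safest expectation is therefore a small one, with the expected step of a 1.3-fold lower number from compound 3 to compound 4 (0.10 log units; within the scatter) staying within the scatter and no clear direction. For compound 4 the estimated value in this assay is 45000 nM, with an expected range from 15000 nM to 100000 nM.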

Compound 4, concentration for 50% growth inhibition: > 100000 nM
Compound 4: no number, only a limit; the forecaster's own chance of this, stated with the estimate: 20%; at least 2.2-fold (0.34 log units) between middle value and limit.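

Putting 3-(allyloxy)phenyl in place of 2-(allyloxy)phenyl on a double-bonded chain carbon bound to a double-bonded ring carbon gives an at least 1.7-fold higher number from compound 3 to compound 4 (0.24 log units; that floor lies within the scatter). Among the compounds shown here, this is the first pair in the set that differs in one place only, and it shows no gain in growth inhibition from this move, since compound 4 gives > 100000 nM, a limit of the assay and not a number. The two compounds have the same atoms, yet only compound 3 gives a real number, and the real size of the step cannot be read because the read-out stops at a ceiling: the limit of > 100000 nM in this assay, at which 2 of the 4 values shown sit.

The set therefore leaves open whether the place of the allyloxy group truly matters, or whether compound 4 differs from compound 3 by no more than the usual scatter of repeated measurements. It also leaves open what would happen if an amine or a carboxylic acid stood on the phenyl ring in place of the allyloxy group, and how much of the activity of the shared core depends on that ring at all.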